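The source may report more compounds than this note shows. Statements on the series, on what has been measured and on what is new or still open speak of the compounds shown alone.

Among the compounds with values here, compound 1 `COc1ccc(-c2[nH]c3ccccc3c2/C=C(\C#N)S(=O)(=O)c2ccccc2)cc1` is the stronger grower-inhibitor of the two compounds measured so far. In a functional assay on SNB-19 cells (Homo sapiens) for inhibition, read by sulforhodamine B assay, with a stated time of 48 h (a lower number here means a stronger inhibitor of growth, a higher number a weaker inhibitor of growth), compound 1 gives 863 nM, the lowest of the two numbers. Compound 2 `CCOC(=O)C(=Cc1c(-c2ccccc2)[nH]c2ccccc12)C(=O)OCC` is built on a different core and carries two ester groups; in this assay compound 2 gives 23900 nM, a number that lies far above that of compound 1 and well beyond the usual scatter.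

Compound 3 `COc1ccc(-c2[nH]c3ccc(OC)cc3c2/C=C(\C#N)S(=O)(=O)c2ccccc2)cc1` is compound 1 with one alteration: methoxy in place of hydrogen on an aromatic carbon. Within the data shown here, no pair of measured compounds shows what such an addition does on this core, so the direction of the step cannot be read from the data. A change of this kind is expected to move the number little, and the step of a 1.2-fold lower number from compound 1 to compound 3 (0.06 log units; within the scatter) is expected to fall within the scatter. Compound 3 is therefore estimated at 750 nM, with a likely range from 250 nM to 2500 nM.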

Compound 3, concentration for 50% growth inhibition: 3200 nM
The estimate for compound 3 lay 4.3-fold (0.63 log units) below the measured number; the measured number lies above the stated range.
By their numbers in this assay, from the lowest: compound 1; then compound 3; then compound 2.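

In this assay, methoxy in place of hydrogen on this aromatic carbon makes the compound a weaker inhibitor of growth, with a 3.7-fold higher number from compound 1 to compound 3 (0.57 log units; beyond the scatter). This position on the six-membered aromatic ring of carbon only therefore does not tolerate every change without effect: a single methoxy, with no ring and no net charge, moves the number beyond the usual scatter. Nothing at hand accounts for the direction or size of this step.

As far as these compounds go, it remains open whether the loss belongs to methoxy itself or would follow any group placed here, such as an amine, a hydroxyl group or a longer chain such as butoxy. From the compounds shown here alone, it is equally open whether methoxy on another carbon of the same ring would give a similar step.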